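Same swap, different core: how far can inhibition climb

The compounds below may be only part of what the source reports. "The series", "measured", "known", "first", "only" and "open" are said of these compounds alone.

Two matched pairs share one structural change. In the first pair, compound 1 `O=C(Nn1c(-c2cccc([N+](=O)[O-])c2)nc2c(-c3ccco3)n[nH]c2c1=O)c1cccnc1` gives 1.66% in a functional assay on DU-145 cells (Homo sapiens) for cytotoxicity, read by sulforhodamine B assay, with a stated time of 2 days, tested at 100 uM (a lower number here means less inhibition, a higher number more inhibition at the concentration tested (going by the name of the read-out)), while compound 2 `COc1cccc(-c2nc3c(-c4ccco4)n[nH]c3c(=O)n2NC(=O)c2cccnc2)c1` gives 30.1% in this assay. The change between them is methoxy in place of nitro on an aromatic carbon, and the step it made was a number 28.4 percentage points higher from compound 1 to compound 2 (beyond the scatter).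

The second pair starts from compound 3 `O=C(Nn1c(-c2cccc([N+](=O)[O-])c2)nc2c(-c3cccc(Cl)c3)n[nH]c2c1=O)c1ccccc1`, which gives 93.8% in this assay, the highest of the three measured numbers. Compound 4 `COc1cccc(-c2nc3c(-c4cccc(Cl)c4)n[nH]c3c(=O)n2NC(=O)c2ccccc2)c1` has not yet been measured. It differs from compound 3 by methoxy in place of nitro on an aromatic carbon. The difference between the core of compound 1 and the core of compound 3 is not broken down here, but the place of the substitution is the same in both pairs, so the change itself is the same.

Whether the step repeats is open. The change from compound 1 to compound 2 raised inhibition, but compound 3 already sits so high that little room remains above it. The expected step from compound 3 to compound 4 in this assay is therefore a number 0.2 percentage points higher from compound 3 to compound 4 (within the scatter), smaller than the earlier one, because compound 3 at 93.8% leaves almost no headroom. Compound 4 is expected to give about 94%, with the estimate falling between 78% and 100%.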

Compound 4, a percentage reported as inhibition, at one concentration (the size of the read-out at that concentration, not a potency): 93.5%
Compound 4: middle estimate off by 0.5 percentage points, on the high side, within the range that was stated.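

On the second core, the swap of 3-nitrophenyl to 3-methoxyphenyl gave a number 0.3 percentage points lower from compound 3 to compound 4 (within the scatter) in this assay. The change therefore did not carry over from one core to the other with the same size of step, and the gap between the two steps is larger than scatter alone would give: the same change on two cores in this assay, a number 28.4 percentage points higher (beyond the scatter) from compound 1 to compound 2 and a number 0.3 percentage points lower (within the scatter) from compound 3 to compound 4, 28.7 percentage points apart, beyond the scatter of two such steps This does not show why the steps differ, since the two pairs cannot separate which part of the difference between the cores matters, nor can they tell whether the flat step only reflects a read-out that was already near its top, with compound 3 at 93.8%, and a reading at a single concentration says nothing about potency.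

The compounds shown carry only nitro or methoxy at this place on the ring, so what an amine or a carboxylic acid there would do in this assay remains open. From the compounds shown here alone, it is also open how the same swap would behave on other cores, in particular on one that starts from a middling value, where a step in either direction would have room to show.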